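The source may hold more compounds than are shown below. What is called first, only, known or untested is meant among the compounds shown, and "the series" means these compounds.

Measured so far:
- compound 1, `COc1cc(-c2cc(/C=C/C(=O)c3ccc(N)cc3)[nH]n2)cc(OC)c1OC`: -55%
- compound 2, `COc1ccc(-c2cc(/C=C/C(=O)c3ccc(OC)c(OC)c3)[nH]n2)cc1`: -40%
- compound 3, `COc1cc(-c2cc(/C=C/C(=O)c3ccc(Cl)c(Cl)c3)[nH]n2)cc(OC)c1OC`: 60%

In a functional assay on SF-268 cells (Homo sapiens) for cytotoxicity, read by sulforhodamine B assay, with a stated time of 48 h, tested at 10 uM (on this read-out higher numbers stand for a weaker effect at the one concentration tested and lower numbers for a stronger effect), compound 3 stands highest of the three numbers; the nearest is compound 2, and the furthest is compound 1, both well beyond the scatter below it. Within the data shown here, the single one-place step measured so far runs a number 115 percentage points higher from compound 1 to compound 3 (beyond the scatter); it is the only step that bears on the present question.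

Compound 4, `COc1ccc(C(=O)/C=C/c2cc(-c3cc(OC)c(OC)c(OC)c3)n[nH]2)cc1`, has not been measured. It differs from compound 3 in one place: 4-methoxyphenyl in place of 3,4-dichlorophenyl on a carbonyl carbon. The step from compound 1 to compound 3 shows that the aryl group on the carbonyl carbon can move the read-out across almost the whole range. Among the measured compounds shown here, compound 4 takes that group back toward an oxygen-bearing aryl, so the step in this assay is expected to run downward, and to be large, though the exact size is uncertain because only one step of this kind is known; compound 2, which carries two methoxy groups on its carbonyl-side aryl, gives -40%, which points the same way without being a one-place comparison.

For compound 4 a value of -20% is expected in this assay, within -80% to 50%, an estimated step of a number 80 percentage points lower from compound 3 to compound 4 (beyond the scatter).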

Compound 4, a percentage reported as activity, at one concentration (the size of the read-out at that concentration, not a potency): -35%
Compound 4: the middle estimate sits 15 percentage points above what was measured, within the range that was stated.
By their numbers in this assay, from the lowest: compound 1; then compounds 2 and 4 (each within the scatter of the next); then compound 3.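

In this assay, the read-out runs a number 95 percentage points lower from compound 3 to compound 4 (beyond the scatter) when 4-methoxyphenyl replaces 3,4-dichlorophenyl on a carbonyl carbon, so the large swing at this position is not tied to the 4-aminophenyl group of compound 1 alone. The position also separates the two groups that leave the read-out low, as methoxy in place of amino on an aromatic carbon gives a number 20 percentage points higher from compound 1 to compound 4 (beyond the scatter) and that smaller step still stands clear of the usual variation between repeats. No measurement at hand accounts for either step.

The three one-place neighbours show only that the 3,4-dichlorophenyl compound sits apart from the 4-methoxyphenyl and 4-aminophenyl compounds, and they cannot say whether both chlorines are needed for that or how a plain phenyl, a phenyl with a single chlorine, or a phenyl with a hydroxyl or a carboxylic acid would read at this position. Also open, from the compounds shown here alone, is whether the same order of groups on the carbonyl carbon would hold if the 3,4,5-trimethoxyphenyl part of the shared core gave way to another aryl group, such as a plain phenyl.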